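Removing a Chloro Group on Two Related Cores

The source may report more compounds than this note shows. Statements on the series, on what has been measured and on what is new or still open speak of the compounds shown alone.

Compound 1 `Clc1ccc(N2N=NCC2c2ccncc2)cc1` and compound 2 `c1ccc(N2N=NCC2c2ccncc2)cc1` are built on the same core. In a functional assay on the whole organism with Mus musculus as the target (on this read-out higher numbers stand for an effect only at larger amounts of compound and lower numbers for an effect already at smaller amounts), compound 1 gives 43.5 mg/kg, and compound 2 gives 107 mg/kg. The change between them is hydrogen in place of chloro on an aromatic carbon and it made a 2.5-fold higher number from compound 1 to compound 2 (0.39 log units; beyond the scatter). Compound 3 `Clc1ccc(-n2nncc2-c2ccccn2)cc1` rests on a different core; the difference between the two cores is not broken down here. In this assay compound 3 gives 50.4 mg/kg, close to compound 1. Compound 4 `c1ccc(-n2nncc2-c2ccccn2)cc1` differs from compound 3 by the same change, (hydrogen in place of chloro on an aromatic carbon), made at the same place as before. Because this change earlier gave a 2.5-fold higher number from compound 1 to compound 2 (0.39 log units; beyond the scatter), the expected step is a 2.5-fold higher number from compound 3 to compound 4 (0.39 log units; beyond the scatter), so a larger dose is anticipated. Compound 4 is estimated in this assay at 125 mg/kg, with a likely range from 70 mg/kg to 230 mg/kg.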

Compound 4, dose for half-maximal effect: 25.6 mg/kg
Compound 4: the middle estimate sits 4.9-fold (0.69 log units) above what was measured, and the stated range ends above it.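

In this assay, putting hydrogen in place of chloro on the second core gives a 2.0-fold lower number from compound 3 to compound 4 (0.29 log units; within the scatter), so the clear rise seen on the first core does not reappear here. The effect of this change therefore does not carry over reliably from one core to the other, as the two steps disagree: the same change on two cores in this assay, a 2.5-fold higher number (0.39 log units; beyond the scatter) from compound 1 to compound 2 and a 2.0-fold lower number (0.29 log units; within the scatter) from compound 3 to compound 4, 4.8-fold (0.69 log units) apart, beyond the scatter of two such steps This does not show why the cores respond differently, and two pairs of compounds give no rule for any further core.

The compounds shown carry only chloro or hydrogen on the six-membered aromatic ring of carbon only. As far as these compounds go, how a fluoro group, a methoxy group or an amine at that place would behave on either core stays open.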